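Trimming the oxime side chain: acetyl to methyl

The compounds below may be only part of what the source reports. "The series", "measured", "known", "first", "only" and "open" are said of these compounds alone.

Measured so far:
compound 1 `CC(=O)/C(=N\O)c1ccc(Sc2cc(F)cc(C3CCOCC3)c2)cc1` — 850 nM
compound 2 `CO[C@]1(c2cnc(S(=O)(=O)c3ccc(/C(C)=N/O)cc3)s2)CCO[C@@H](C)C1` — 320 nM

In a functional assay (blood) for inhibition, with Homo sapiens as the target (a higher number here means a weaker inhibitor, a lower number a stronger inhibitor), compound 1 gives 850 nM, the highest of the two numbers; compound 2, with 320 nM, sits lower by a gap beyond the usual scatter. Compound 3 `C/C(=N\O)c1ccc(Sc2cc(F)cc(C3CCOCC3)c2)cc1` is compound 1 with one change: methyl in place of acetyl on a carbon with a double bond to nitrogen. Among the measured compounds shown here, no measured pair shows this change, so the size of the step is uncertain. The change is expected to give at most a modest step, probably none beyond the scatter, with a slight lean toward a lower number, as in a 1.4-fold lower number from compound 1 to compound 3 (0.15 log units; within the scatter). Compound 3 is therefore estimated at 600 nM, within 200 nM to 1800 nM.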

Compound 3, half-maximal inhibitory concentration: 80 nM
Compound 3: the middle estimate sits 7.5-fold (0.88 log units) above what was measured, and the stated range ends above it.
By their numbers in this assay, from the lowest: compound 3; then compound 2; then compound 1.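

In this assay, methyl in place of acetyl on a carbon with a double bond to nitrogen gives an 11-fold lower number from compound 1 to compound 3 (1.03 log units; beyond the scatter) and so counts as a large step beyond the scatter. This position on the oxime side chain is therefore far from indifferent to the group it carries, and a smaller group is favoured here in this single pair. Nothing available explains the size of the step. On these data alone, whether ethyl, a longer chain or an amine on that carbon would sit nearer methyl or acetyl remains open. So does whether the step holds on another core.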